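Cyclopropyl for Trifluoromethylbenzyl: Expectation in the Rat Plasma Assay

The compounds below may be only part of what the source reports. "The series", "measured", "known", "first", "only" and "open" are said of these compounds alone.

Measured in an ADME assay on a cell-free system (plasma, Rattus norvegicus), with a stated time of 60 min; a higher number here means that more of the compound is left, a lower number that less of the compound is left:
compound 1, `O=C(O)c1cc(-c2cccc(COc3ccc4c(c3)CN(Cc3ccc(C(F)(F)F)cc3)C4=O)c2)ccc1Cl`: 100%
compound 2, `O=C(O)c1cc(-c2cccc(COc3ccc4c(c3)CN(c3ccccc3)C4=O)c2)ccc1Cl`: 100%
compound 3, `CC(C)N1Cc2cc(OCc3cccc(-c4ccc(Cl)c(C(=O)O)c4)c3)ccc2C1=O`: 98%

Compound 1 stands level with compound 2 in this assay; the step of no change at the digits printed from compound 1 to compound 2 (within the scatter) lies within the scatter, as does the step to the furthest neighbour, a number 2 percentage points lower from compound 1 to compound 3 (within the scatter). The remaining measured step, a number 2 percentage points lower from compound 2 to compound 3 (within the scatter), is likewise within the scatter. All three compounds share the same core and differ only in the group on the amide-type nitrogen in the ring, and none of these changes moved the read-out beyond the usual variation.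

Compound 4, `O=C(O)c1cc(-c2cccc(COc3ccc4c(c3)CN(C3CC3)C4=O)c2)ccc1Cl`, differs from compound 1 by cyclopropyl in place of 4-(trifluoromethyl)benzyl on an amide-type nitrogen in a ring. The three measured steps all bear on this change, since each exchanges the group at the same place, and each was small: benzyl-type, phenyl and isopropyl groups all left the compound essentially intact in this assay. No step beyond the scatter is therefore expected for compound 4 in this assay. The expected step is a number 1 percentage points lower from compound 1 to compound 4 (within the scatter), which is within the scatter. Compound 4 is estimated to give 99%, with a range from 90% to 100%.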

Compound 4, percent of the compound remaining: 100%
For compound 4 the middle estimate is 1 percentage points below the measured one; measured number inside the range.
By their numbers in this assay, from the lowest: compounds 3, 1, 2 and 4 (each within the scatter of the next).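

In this assay, the exchange of 4-(trifluoromethyl)benzyl, with 11 heavy atoms, for cyclopropyl, with 3, gives no change at the digits printed from compound 1 to compound 4 (within the scatter) and so shows that the amide-type nitrogen in a ring also tolerates this much smaller group, which has no six-membered aromatic ring and no fluorine. The other two new steps, a number 2 percentage points higher from compound 3 to compound 4 (within the scatter) and no change at the digits printed from compound 2 to compound 4 (within the scatter) as well, leave the four groups at this place indistinguishable in this read-out. Nothing available bears on why the read-out stays flat at this position.

The compounds shown leave open whether an amine or a longer chain on this nitrogen would give the same picture in this assay as well. They also leave open whether an ester in place of the carboxylic acid of the shared core would do so.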